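The source may report more compounds than this note shows. Statements on the series, on what has been measured and on what is new or still open speak of the compounds shown alone.

Compound 1 `CCc1cc2c(N/N=C\c3cccs3)ncnc2s1`: 0.566 ug/mL
Compound 2 `CC(C)c1cc2c(N/N=C\c3ccccn3)ncnc2s1`: 0.003 ug/mL
Compound 3 `CC(C)(C)c1cc2c(N/N=C\c3ccccn3)ncnc2s1`: 0.009 ug/mL

In a functional assay on PC-6 cells (Homo sapiens) for antiproliferative activity (on this read-out lower numbers stand for stronger inhibition and higher numbers for weaker inhibition), compound 3 holds the second highest number of the three. Its nearest neighbour is compound 2, reached by a 3.0-fold higher number from compound 2 to compound 3 (0.48 log units; beyond the scatter); compound 1 gives a far higher number, so compound 3 sits much closer to compound 2 than to compound 1.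

Compound 4 `CN(C)Cc1cccc(/C=N\Nc2ncnc3sc(C(C)(C)C)cc23)n1` has not been measured. It differs from compound 3 by (dimethylamino)methyl in place of hydrogen on an aromatic carbon, the new group sitting next to the ring nitrogen and meta to a large group. Within the data shown here, the single measured step concerns the saturated chain on the other side of the shared core and says nothing about additions to this six-membered ring, so no step beyond the scatter is expected in this assay. Compound 4 is therefore estimated at 0.015 ug/mL, with a range from 0.004 ug/mL to 0.06 ug/mL. That estimate corresponds to an expected step of a 1.7-fold higher number from compound 3 to compound 4 (0.22 log units; within the scatter).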

Compound 4, half-maximal inhibitory concentration: 0.381 ug/mL
Beside the measured number, compound 4's estimate is 25-fold (1.40 log units) below it; measured number outside the range, above it.
By their numbers in this assay, from the lowest: compound 2; then compound 3; then compounds 4 and 1 (each within the scatter of the next).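

In this assay, among these compounds, placing (dimethylamino)methyl on the six-membered aromatic ring, next to the ring nitrogen, costs far more (a 42-fold higher number from compound 3 to compound 4 (1.63 log units; beyond the scatter)) than the only earlier single change on the saturated chain (a 3.0-fold higher number from compound 2 to compound 3 (0.48 log units; beyond the scatter)). This ring position is therefore sensitive to substitution, which the chain change could not reveal. No measurement here explains this loss of inhibition.

Going by these compounds, it remains open whether a plain methyl at this place would cost as much as (dimethylamino)methyl. A morpholinomethyl or aminomethyl group there would help show whether the dimethylamino part matters.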